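Pyridin-2-yl to 3,4-difluorophenyl: one change, one expectation

A few compounds are considered here, and "the series" means these few. Any claim that something is new, unique, unknown or untested is made for them only; others in the source may bear on it.

Compound 1 `Cc1cc(NC(=O)Cn2nnc(-c3ccccc3)n2)n(C2CCOCC2)n1`: 115%
Compound 2 `CC1(c2cc(NC(=O)Cn3nnc(-c4ccccc4)n3)n(C3CCCCC3)n2)CC1`: > 10%, a limit of the assay rather than a number
Compound 3 `Cc1cc(NC(=O)Cn2nnc(-c3ccccn3)n2)n(C2CCCCC2)n1`: 81%

Of the compounds shown here, three have been measured in an assay on HEK293 cells for activation of Kir3.1/Kir3.2 (Homo sapiens), read by thallium flux; a higher number here means a larger maximal response, a lower number a smaller maximal response. Compound 3 holds the lower of the two numbers there; the nearest number is that of compound 1, and the gap between them lies beyond the usual scatter. The two compounds differ in more than one place, so the gap cannot be tied to a single change. For compound 2 the assay gives only a limit (the limit of > 10% in this assay, at which 1 of the 3 values shown sits).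

The unmeasured compound 4 `Cc1cc(NC(=O)Cn2nnc(-c3ccc(F)c(F)c3)n2)n(C2CCCCC2)n1` follows from compound 3 by one alteration: 3,4-difluorophenyl in place of pyridin-2-yl on an aromatic carbon. Among the measured compounds shown here, no measured pair isolates this exchange, so no step size is known for it. The writer expects the change to move the maximal response little, either way, and most likely within the scatter. For compound 4 the estimated value in this assay is 90%, expected to fall between 60% and 120%, which means an expected step of a number 9 percentage points higher from compound 3 to compound 4 (within the scatter).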

Compound 4, largest response reached (Emax), in percent of the reference or control that the assay uses: 93%
Beside the measured number, compound 4's estimate is 3 percentage points below it; measured number inside the range.
By their numbers in this assay, from the lowest: compound 3; then compound 4; then compound 1.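

The position on the aromatic carbon of the five-membered aromatic ring with 4 nitrogen now has its first isolated exchange: 3,4-difluorophenyl in place of pyridin-2-yl gives a number 12 percentage points higher from compound 3 to compound 4 (beyond the scatter) in this assay. The step is modest, but it shows that this position accepts a ring of carbon only, with two fluorine atoms and without the hydrogen-bond acceptor of pyridin-2-yl, with no fall in the maximal response. Nothing measured here accounts for the size or direction of this step.

The compounds shown leave open whether the step follows from losing the ring nitrogen or from adding the two fluorine atoms. They also leave open how the position would respond to a carboxylic acid, an amine or an open alkyl chain in place of the aromatic ring.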